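Working notes: formyl in place of chloro

The source may hold more compounds than are shown below. What is called first, only, known or untested is meant among the compounds shown, and "the series" means these compounds.

In a functional assay on A549 cells (Homo sapiens) for cytotoxicity, read by MTT assay, with a stated time of 48 h (a lower number here means a stronger inhibitor, a higher number a weaker inhibitor), compound 1 `O=c1cc(-c2ccc(Cl)cc2)nc2ccccn12` gives 2100 nM and compound 2 `O=c1c(-c2ccccc2)cnc2c(OCc3ccccc3)cccn12` gives 2000 nM. Among the measured compounds shown here, these two values lie within the scatter of each other, so compound 1 does not separate from the only other measured compound. For the measured compounds named here, the two structures differ in more than one place, and no measured step isolates a single change.

Compound 3 `O=Cc1ccc(-c2cc(=O)n3ccccc3n2)cc1` keeps the core of compound 1 and carries formyl in place of chloro on an aromatic carbon of a six-membered aromatic ring of carbon only, para to a large group: formyl in place of chloro on an aromatic carbon. Going by the values given here, no measured pair shows the effect of this exchange, so the data give no direction for it. In this assay, no step beyond the scatter is expected, though the basis for this is thin. The estimate is a 1.2-fold higher number from compound 1 to compound 3 (0.08 log units; within the scatter), a small expected step. For compound 3 the estimated value is 2500 nM, with an expected range from 900 nM to 7000 nM.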

Compound 3, half-maximal inhibitory concentration: 2400 nM
For compound 3 the middle estimate is 1.0-fold (0.02 log units) above the measured one, within the range that was stated.
By their numbers in this assay, from the lowest: compounds 2, 1 and 3 (each within the scatter of the next).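

In this assay, formyl in place of chloro on an aromatic carbon, para to a large group, gives a 1.1-fold higher number from compound 1 to compound 3 (0.06 log units; within the scatter). Among the compounds shown here, this is the first step that isolates a single change, and it shows that on the core of compound 1 this exchange, in which one chlorine leaves and a carbon and an oxygen enter along with a hydrogen-bond acceptor and a double bond outside aromatic rings, does not separate the two compounds in this read-out. No measurement is available that would account for this result or tie it to any property of either group.

The compounds shown cover only this one exchange at this one place, so a single step within the scatter cannot show whether the read-out responds to changes here at all. On these data alone, whether an amine, a carboxylic acid or a longer chain on the same aromatic carbon would also stay within the scatter of compound 1 remains open, as does the effect of a hydroxyl or a methoxy group there.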